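Phenoxy Extension on the Triazole Aryl Ring

The source may report more compounds than this note shows. Statements on the series, on what has been measured and on what is new or still open speak of the compounds shown alone.

This set holds three measured compounds and one still to be tested. Compound 1 `O=C(N1C[C@H](O)C=C[C@H]1COCc1ccccc1)n1cc(-c2ccc(-c3ccccc3)cc2)nn1` gives only a limit in an assay on HEK293 cells for inhibition of diacylglycerol lipase-alpha (Homo sapiens), read by colorimetric assay, with stated times of 30 min, 60 s and 20 min (a lower number here means a stronger inhibitor, a higher number a weaker inhibitor), namely > 10000 nM, and this value is a limit of the assay rather than a number (the limit of > 10000 nM in this assay, at which 1 of the 3 values shown sits). Compound 2 `O=C(N1C[C@H](O)C=C[C@@H]1Cc1ccccc1)n1cc(-c2ccc(-c3ccccc3)cc2)nn1` gives 15.9 nM in this assay. Compound 3 `O=C(N1CCC=C[C@@H]1COCc1ccccc1)n1cc(-c2ccccc2)nn1` gives 158 nM, which is the highest of the two numbers shown; compound 2 sits at a lower number, and the gap between them lies beyond the usual scatter. Among the measured compounds shown here, compounds 2 and 3 differ in more than one place, so no single step connects them.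

Compound 4 `O=C(N1CCC=C[C@@H]1COCc1ccccc1)n1cc(-c2ccc(Oc3ccccc3)cc2)nn1` is the next compound. It differs from compound 3 in one place: phenoxy in place of hydrogen on an aromatic carbon. For the measured compounds named here, since no measured pair shows this exact change, the size of the step is uncertain. It is expected, however, that the phenoxy group lowers the number, and the step from compound 3 to compound 4 is estimated as a 4.0-fold lower number from compound 3 to compound 4 (0.60 log units; beyond the scatter) in this assay. On that basis compound 4 is expected to give 40 nM, with a range from 10 nM to 200 nM.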

Compound 4, half-maximal inhibitory concentration: 25.1 nM
Beside the measured number, compound 4's estimate is 1.6-fold (0.20 log units) above it; the range from low to high includes it.
By their numbers in this assay, from the lowest: compounds 2 and 4 (each within the scatter of the next); then compound 3. At a limit, above all of these: compound 1.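

In this assay, phenoxy in place of hydrogen on an aromatic carbon, para to a large group, gives a 6.3-fold lower number from compound 3 to compound 4 (0.80 log units; beyond the scatter), a change confined to one place. The earlier compounds shown here offered no pair that differed in one place, so they could not show whether this position on the aromatic ring responds to a change at all; this step shows that it does, and that a group bringing a further six-membered aromatic ring through an oxygen is compatible with a lower number there. The finding rests on this single pair, and nothing measured in this set accounts for the size of the step.

The compounds shown leave open whether the step is particular to phenoxy or would also follow from other groups at the same place, such as methoxy, benzyloxy, an amine or a carboxylic acid. They also leave open whether phenoxy would produce a step of similar size on the core of compound 2.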